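A Meta Ester Replaces the Dimethoxy Pattern

The source may report more compounds than this note shows. Statements on the series, on what has been measured and on what is new or still open speak of the compounds shown alone.

Compound 1 `CCS(=O)(=O)Nc1cc(-c2ccc3ncnc(Nc4cccc(F)c4)c3c2)cnc1OC` and compound 2 `CCS(=O)(=O)Nc1cc(-c2ccc3ncnc(Nc4ccc(OC)c(OC)c4)c3c2)cnc1OC` share one core and differ only in the aryl group on the nitrogen on an aromatic ring. In a functional assay on SNU-638 cells (Homo sapiens) for cytotoxicity, read by sulforhodamine B assay, with a stated time of 72 h (on this read-out higher numbers stand for weaker inhibition and lower numbers for stronger inhibition), compound 1 gives 2760 nM, and in this assay compound 2 gives 1680 nM. The step of a 1.6-fold lower number from compound 1 to compound 2 (0.22 log units; within the scatter) is the only one measured so far, and it stays within the scatter. Compound 2 thus holds the lower of the two numbers, but its gap to compound 1 is no more than repeated measurements would show.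

Compound 3 `CCS(=O)(=O)Nc1cc(-c2ccc3ncnc(Nc4cccc(C(=O)OC)c4)c3c2)cnc1OC` follows from compound 2 by the change (3-(methoxycarbonyl)phenyl in place of 3,4-dimethoxyphenyl on a nitrogen on an aromatic ring). Among the compounds with values here, the one step that bears on it, a 1.6-fold lower number from compound 1 to compound 2 (0.22 log units; within the scatter), swapped one aryl group for another at the same place without moving the number beyond the scatter. On that basis the step of a 1.2-fold higher number from compound 2 to compound 3 (0.08 log units; within the scatter) is expected to be small, with no firm direction. Compound 3 is therefore estimated to give 2000 nM in this assay, within a range from 700 nM to 6000 nM.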

Compound 3, half-maximal inhibitory concentration: 1120 nM
Compound 3: the middle estimate sits 1.8-fold (0.25 log units) above what was measured, and the stated range covers the measured number.
By their numbers in this assay, from the lowest: compounds 3, 2 and 1 (each within the scatter of the next, the first and the last beyond it).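

In this assay the exchange of 3,4-dimethoxyphenyl for 3-(methoxycarbonyl)phenyl on the nitrogen gives a 1.5-fold lower number from compound 2 to compound 3 (0.18 log units; within the scatter) and so stays within the scatter, although the two groups match in heavy atoms, hydrogen-bond donors and acceptors and differ by one double bond outside aromatic rings. Compound 3 also provides the first step beyond the scatter among the compounds shown: a 2.5-fold lower number from compound 1 to compound 3 (0.39 log units; beyond the scatter) is a modest change, with methoxycarbonyl in place of fluoro on an aromatic carbon, and it shows that the aryl group on the nitrogen can move the number measurably, though only by a small margin. No measurement among the data offers an explanation for either step.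

On these data alone, what remains open is whether this modest gain belongs to the methoxycarbonyl group itself, or whether a carboxylic acid, a primary amide or an ethoxycarbonyl group at the same place would give a similar number. The compounds shown also leave open whether an amine on this aryl group would move the number further, in either direction, from where compound 3 stands.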